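The source may report more compounds than this note shows. Statements on the series, on what has been measured and on what is new or still open speak of the compounds shown alone.

Compound 2 `Cc1cc(Nc2nc(Nc3ccc(C(=O)NC4CC(C)(C)N([O])C(C)(C)C4)cc3)ncc2F)n[nH]1`: 11200 nM
Compound 3 `CC(C)OC(=O)Cc1csc(Nc2nc(Nc3ccc(C(=O)NC4CC(C)(C)N([O])C(C)(C)C4)cc3)ncc2F)n1`: 11200 nM
Compound 1 `Cc1cc(Nc2nc(Nc3ccc(C(=O)NC4CC(C)(C)N([O])C(C)(C)C4)cc3)ncc2F)no1`: 5680 nM

In a functional assay on HeLa cells (Homo sapiens) for antiproliferative activity, read by MTT assay, with a stated time of 48 h (on this read-out lower numbers stand for stronger inhibition and higher numbers for weaker inhibition), compound 2 stands level with compound 3, the two together the highest of the three numbers; compound 1 gives a lower number, yet a 2.0-fold higher number from compound 1 to compound 2 (0.29 log units; within the scatter) and a 2.0-fold higher number from compound 1 to compound 3 (0.29 log units; within the scatter) are both within the scatter, so no order among the three can be read. Compound 4 `CCCCOC(=O)Cc1cc(Nc2nc(Nc3ccc(C(=O)NC4CC(C)(C)N([O])C(C)(C)C4)cc3)ncc2F)n[nH]1` differs from compound 2 by butoxycarbonyl in place of hydrogen on a saturated chain carbon bound to an aromatic carbon; cut one bond further out, this reads methyl to (butoxycarbonyl)methyl. Within the data shown here, the only measured step that comes near it is no change at the digits printed from compound 2 to compound 3 (within the scatter), where an ester-bearing chain enters together with a different ring, and it was flat. Compound 4 is thus expected to show a 1.0-fold lower number from compound 2 to compound 4 (0.01 log units; within the scatter). The estimate for compound 4 is 11000 nM, between 4500 nM and 28000 nM.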

Compound 4, half-maximal inhibitory concentration: 2720 nM
For compound 4 the middle estimate is 4.0-fold (0.61 log units) above the measured one; the measured number lies below the stated range.
By their numbers in this assay, from the lowest: compound 4; then compounds 1, 2 and 3 (each within the scatter of the next).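

In this assay, replacing methyl with (butoxycarbonyl)methyl gives a 4.1-fold lower number from compound 2 to compound 4 (0.61 log units; beyond the scatter), the only step among these compounds that lies beyond the scatter. This shows that the read-out responds to a change at this saturated chain carbon bound to an aromatic carbon, which the flat steps among compounds 1, 2 and 3 could not show. Nothing available explains the step.

The compounds shown leave open whether the ester or the chain length matters. A carboxylic acid, a methyl ester or an amide at this place would help separate the two.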